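Swapping a Branched Amine for an Imidazole Ring

The source may report more compounds than this note shows. Statements on the series, on what has been measured and on what is new or still open speak of the compounds shown alone.

Measured so far:
Compound 1 `Fc1ccc(/C=N/NC(=S)Nc2nc3ccc(Cl)cc3s2)cc1` gives 100 mg/kg
Compound 2 `CC(C)(C)NCC(=O)Nc1nc2ccc(Cl)cc2s1` gives 100 mg/kg
Compound 3 `O=[N+]([O-])c1ccc(/C=N/NC(=S)Nc2nc3ccc(Cl)cc3s2)cc1` gives 300 mg/kg

All three share one core and were tested in a functional assay on the whole organism with Mus musculus as the target, with a stated time of 0.5 h; on this read-out higher numbers stand for an effect only at larger amounts of compound and lower numbers for an effect already at smaller amounts. Compound 2 stands level with compound 1 at the digits recorded, and together these two hold the lowest numbers of the three. Among the compounds with values here, compound 3 sits apart: the single measured step, a 3.0-fold higher number from compound 1 to compound 3 (0.48 log units; beyond the scatter), is a modest change that lies beyond the usual scatter.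

Compound 4 `O=C(Cn1ccnc1)Nc1nc2ccc(Cl)cc2s1` is the untested member. It differs from compound 2 in one place: 1H-imidazol-1-yl in place of (tert-butyl)amino on a saturated chain carbon bound to a carbonyl carbon. Within the data shown here, this change sits on the amide side chain, whereas the only measured step concerns a substituent on an aromatic carbon of a different arm, so no measured step bears directly on what compound 4 should show. Without a comparable step, the safest expectation is that compound 4 stays close to compound 2, with any shift falling within the scatter.

Compound 4 is therefore estimated at 100 mg/kg in this assay, with a likely range from 30 mg/kg to 300 mg/kg. The expected step from the measured parent is no change at the digits printed from compound 2 to compound 4 (within the scatter).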

Compound 4, minimum effective dose: 100 mg/kg
Compound 4: the middle estimate sits on the measured number at the digits printed; the range from low to high includes it.
By their numbers in this assay, from the lowest: compounds 1, 2 and 4 (each within the scatter of the next); then compound 3.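

In this assay, within the data shown here, the change on the saturated chain carbon bound to a carbonyl carbon gives no change at the digits printed from compound 2 to compound 4 (within the scatter), the first read on this position, since the only earlier step concerned a substituent on an aromatic carbon of a different arm. The two groups differ widely in form: (tert-butyl)amino has no ring and 1 hydrogen-bond donor, whereas 1H-imidazol-1-yl is a five-membered aromatic ring with 2 hetero atoms and 0 hydrogen-bond donors, though each holds 5 heavy atoms. This position can therefore take either group with no visible effect on the read-out, but no data here explain why the two groups read alike.

A phenyl ring in the same place would show whether an aromatic ring without nitrogen reads the same way as the imidazole, and a plain amino group would show whether the tert-butyl part matters at all. A carboxylic acid on this carbon, or a longer chain between the carbonyl and the imidazole, also remains an open case.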